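A few compounds are considered here, and "the series" means these few. Any claim that something is new, unique, unknown or untested is made for them only; others in the source may bear on it.

Of the compounds shown here, three of this set have been measured in a functional assay on SiHa cells (Homo sapiens) for cytotoxicity, read by MTT assay, with a stated time of 48 h; on this read-out lower numbers stand for stronger inhibition and higher numbers for weaker inhibition. Compound 1 `CCCCCCCCCCCCCCNC(=O)[C@@H](N)[C@@H](C)O` gives 11000 nM, compound 2 `CCCCCCCCCCCCCCCCCCNC(=O)[C@@H](N)[C@@H](C)O` gives 39500 nM, and compound 3 `CCCCCCCCNC(=O)[C@@H](NC(=O)/C=C/c1ccccc1)[C@@H](C)O` gives 41400 nM. Compound 2 thus stands second highest of the three numbers: the step of a 3.6-fold higher number from compound 1 to compound 2 (0.56 log units; beyond the scatter) lies beyond the scatter, while compound 3 lies within the scatter of compound 2. Compound 4 `CCCCCCCCCCCCCCCCCCNC(=O)[C@@H](NC(=O)c1cccs1)[C@@H](C)O` differs from compound 2 in one place: (thiophen-2-yl)carbonyl in place of hydrogen on an amine nitrogen. Within the data shown here, no measured pair differs by this change alone; the single recorded step, a 3.6-fold higher number from compound 1 to compound 2 (0.56 log units; beyond the scatter), concerns the chain and does not bear on acylation of the amine. Compound 3, which carries an acyl group on the amine nitrogen together with a shorter chain, gives a number indistinguishable from that of compound 2, so nothing points to a large shift in either direction. One therefore expects no step beyond the scatter and estimates compound 4 at 40000 nM, with a range from 15000 nM to 110000 nM. The step of a 1.0-fold higher number from compound 2 to compound 4 (0.01 log units; within the scatter) is the expected outcome.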

Compound 4, half-maximal inhibitory concentration: 117000 nM
Estimate against measurement, compound 4: 2.9-fold (0.47 log units) below, and the stated range ends below it.
By their numbers in this assay, from the lowest: compound 1; then compounds 2 and 3 (each within the scatter of the next); then compound 4.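

Among these compounds, putting (thiophen-2-yl)carbonyl in place of hydrogen on the amine nitrogen is the only step at this position that can be read on its own, and in this assay it gives a 3.0-fold higher number from compound 2 to compound 4 (0.47 log units; beyond the scatter), a modest change toward weaker inhibition. This shows that, with the chain of compound 2 kept, the amine nitrogen is not indifferent to this substitution: of the pair, the compound with the free amine gives the stronger inhibition. Nothing available bears on why this step occurs.

From the compounds shown here alone, whether an acetyl or benzoyl group, or a methyl group, on this nitrogen would give a similar step remains open. Going by these compounds, it also remains open whether (thiophen-2-yl)carbonyl would give the same step on the shorter chain of compound 1.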